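A few compounds are considered here, and "the series" means these few. Any claim that something is new, unique, unknown or untested is made for them only; others in the source may bear on it.

Measured so far in a functional assay on the whole organism for inhibition, with Scenedesmus acutus as the target; a lower number here means a stronger inhibitor, a higher number a weaker inhibitor:
- compound 1 `CC(C)COC(=O)c1cc(N2C(=O)C3=C(CCCC3)C2=O)ccc1Cl`: 977 nM
- compound 2 `CCCCCOC(=O)c1cc(N2C(=O)C3=C(CCCC3)C2=O)ccc1Cl`: 4470 nM

Compound 2 holds the higher of the two numbers, at 4470 nM, and so is the weaker inhibitor of the pair. The next compound to be measured is compound 3 `CCCCCCCCOC(=O)c1cc(N2C(=O)C3=C(CCCC3)C2=O)ccc1Cl`, which lengthens the chain of compound 2: propyl in place of hydrogen on a saturated chain carbon, five bonds along the chain from an oxygen next to a carbonyl group. In words, this is propyl in place of hydrogen on a saturated chain carbon, five bonds along the chain from an oxygen next to a carbonyl group.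

For the measured compounds named here, only one measured step bears on this change: a 4.6-fold higher number from compound 1 to compound 2 (0.66 log units; beyond the scatter). That step, butyl in place of isopropyl, is modest, and it alters the chain at a different carbon from the one changed here. Going by the values given here, no measured compound carries a chain as long as that of compound 3, so the direction rests on this single step alone. A further rise in the number in this assay is expected, of broadly similar size, with wide uncertainty. The expected change is a 2.0-fold higher number from compound 2 to compound 3 (0.30 log units; within the scatter). For compound 3 the estimated value is 9000 nM, with an expected range of 2000 nM to 40000 nM.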

Compound 3, half-maximal inhibitory concentration: > 100000 nM
Compound 3: only a limit was reported; the forecaster's own chance of this, stated with the estimate: 10%; middle value at least 11-fold (1.04 log units) from the limit.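

In this assay compound 3 gives > 100000 nM, which is a limit of the assay and not a number, so the true size of the change at this position is bounded from one side only: the limit of > 100000 nM in this assay, at which 1 of the 3 values shown sits.

Even so, adding propyl on the saturated chain carbon five bonds along the chain from an oxygen next to a carbonyl group gives an at least 22-fold higher number from compound 2 to compound 3 (1.34 log units; beyond the scatter), a large step where the earlier 4.6-fold higher number from compound 1 to compound 2 (0.66 log units; beyond the scatter) was modest, so lengthening the chain here is far from neutral. Heptyl in place of isopropyl on the carbon bound to that oxygen gives an at least 100-fold higher number from compound 1 to compound 3 (2.01 log units; beyond the scatter), and among these three compounds the number rises in the order compound 1, compound 2, compound 3, with none going against that order.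

Still open, on these data alone, is whether the number climbs steadily or abruptly between butyl and heptyl on that carbon, which a hexyl chain there could help to settle. Also open, as far as these compounds go, is whether a shorter chain such as ethyl would fall below the number of compound 1, and whether a carboxylic acid at the end of the long chain would change the outcome for compound 3.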